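The compounds below may be only part of what the source reports. "The series", "measured", "known", "first", "only" and "open" are said of these compounds alone.

Working notes on the series

The shared core of compound 1 `Cc1cc(NC(=O)c2ccc(Cl)cc2)ccc1NS(=O)(=O)C(F)(F)F` carries an amide linking two aromatic rings, with a trifluoromethyl sulfonamide on one side. In an ADME assay on HEK293 cells (Homo sapiens) for cytotoxicity, read by MTT assay, with a stated time of 48 h (on this read-out higher numbers stand for weaker inhibition and lower numbers for stronger inhibition), compound 1 gives 201000 nM. Compound 2 `Cc1cc(NC(=O)c2ccc(C#N)cc2)ccc1NS(=O)(=O)C(F)(F)F` keeps that core and differs only in the change (cyano in place of chloro on an aromatic carbon). For compound 2 this assay reports only a limit, > 250000 nM. The step of an at least 1.2-fold higher number from compound 1 to compound 2 (0.09 log units; that floor lies within the scatter) therefore runs from a number to the floor of the assay, and its size is known only as a lower bound.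

Compound 3 `CCS(=O)(=O)Nc1ccc(NC(=O)c2ccc(Cl)cc2)cc1Cl` has a different core from compound 1: an ethyl sulfonamide and a chloro on the sulfonamide-bearing ring; the difference between the two cores is not broken down here. For compound 3 this assay also reports only a limit, > 250000 nM. Two of the three values shown sit at the limit of > 250000 nM in this assay, at which 2 of the 3 values shown sit.

Compound 4 `CCS(=O)(=O)Nc1ccc(NC(=O)c2ccc(C#N)cc2)cc1Cl` stands to compound 3 as compound 2 stands to compound 1, through the same change (cyano in place of chloro on an aromatic carbon), at the same place in both pairs. The expected step that the limit leaves unreadable from compound 3 to compound 4 is taken to be no larger than the earlier one, which already ended at the limit. This rests on the step of an at least 1.2-fold higher number from compound 1 to compound 2 (0.09 log units; that floor lies within the scatter) reaching the limit (the limit of > 250000 nM in this assay, at which 2 of the 3 values shown sit), and on compound 3 sitting at that limit before the change. Compound 4 is therefore expected to give about 300000 nM in this assay, most likely reported as a limit again, in a range from 150000 nM to 600000 nM.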

Compound 4, half-maximal inhibitory concentration: > 250000 nM
Compound 4 was reported as a limit; the forecaster's own chance of this, stated with the estimate: 85%; the middle value does not contradict the limit.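

In this assay, within the data shown here, compound 3 and compound 4 are both reported only as limits, so no step between them can be read: the limit of > 250000 nM in this assay, at which 3 of the 4 values shown sit. The compounds shown leave open how far compound 2, compound 3 and compound 4 lie past that limit, and whether cyano in place of chloro changes the read-out at all on the core of compound 3.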